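A second methoxy on the aromatic ring of compound 2

The source may report more compounds than this note shows. Statements on the series, on what has been measured and on what is new or still open speak of the compounds shown alone.

Values in an ADME assay on microsomes from liver (Homo sapiens) for metabolic stability; on this read-out lower numbers stand for slow clearance and higher numbers for fast clearance:
- Compound 1 `C[C@H](NC(=O)Cn1nnc2ccccc2c1=O)c1ccc(Cl)cc1`: < 9.9 mL/min/kg, a limit of the assay and not a number
- Compound 2 `COc1ccc([C@H](C)NC(=O)Cn2nnc3ccccc3c2=O)cc1`: 13 mL/min/kg
- Compound 3 `Cc1ccc([C@H](C)NC(=O)Cn2nnc3ccccc3c2=O)c(F)c1`: 28 mL/min/kg
- Compound 4 `COc1ccc([C@H](C)NC(=O)Cn2nnc3ccccc3c2=O)c(OC)c1`: not yet measured

Of the two values that are true numbers, the lower belongs to compound 2. Compound 4 differs from it by one change: methoxy in place of hydrogen on an aromatic carbon. Methoxy takes the place of hydrogen on an aromatic carbon, ortho to a large group and meta to a methoxy group.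

Going by the values given here, no measured step makes exactly this change, so the comparison is loose. The closest is a 2.2-fold higher number from compound 2 to compound 3 (0.33 log units; beyond the scatter), where 2-fluoro-4-methylphenyl replaces 4-methoxyphenyl. Changes to the aromatic ring also gave an at least 2.8-fold higher number from compound 1 to compound 3 (0.45 log units; beyond the scatter) and an at least 1.3-fold higher number from compound 1 to compound 2 (0.11 log units; that floor lies within the scatter). These steps all point upward, so a modest rise toward faster clearance in this assay is expected, though a step within the scatter remains possible. The expected change is a 1.5-fold higher number from compound 2 to compound 4 (0.19 log units; within the scatter). For compound 4 the estimated clearance is 20 mL/min/kg, with an expected range from 10 mL/min/kg to 40 mL/min/kg.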

Compound 4, clearance: 24 mL/min/kg
Compound 4: the middle estimate sits 1.2-fold (0.08 log units) below what was measured; low and high end bracket the measured number.
By their numbers in this assay, from the lowest: compounds 2, 4 and 3 (each within the scatter of the next, the first and the last beyond it). At a limit, below all of these: compound 1.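

Earlier steps swapped one group or ring pattern for another, whereas this one adds a single group and leaves the rest of compound 2 in place: methoxy in place of hydrogen, ortho to a large group and meta to a methoxy group. In this assay, that addition gives a 1.8-fold higher number from compound 2 to compound 4 (0.27 log units; within the scatter), so this position takes a second methoxy with no difference that can be told apart from the scatter of repeated measurements. Nothing shown gives a cause for this step.

Going by these compounds, how far this holds for other groups at the same position stays open, for instance a hydroxyl, an amine or a carboxylic acid. On these data alone, it is equally open whether a longer chain there, such as ethoxy, would read like methoxy.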